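Urea to amide at the carbonyl carbon: compound 4

The source may report more compounds than this note shows. Statements on the series, on what has been measured and on what is new or still open speak of the compounds shown alone.

Compound 3 `COc1cc(Cl)cc(-c2nn(-c3cccc(NC(=O)Nc4cccc(C(F)(F)F)c4)c3)cc2-c2ccncc2)c1` gives 82% in a functional assay on SK-MEL-28 cells (Homo sapiens) for inhibition, read by sulforhodamine B assay, with a stated time of 48 h, tested at 1 uM; a higher number here means a weaker effect of the compound at the concentration tested, a lower number a stronger effect; this is the smallest of the three numbers, yet compound 1 `COc1cc(Cl)cc(-c2nn(-c3cccc(NC(=O)Nc4ccc(Cl)c(C(F)(F)F)c4)c3)cc2-c2ccncc2)c1` at 85% and compound 2 `COc1cc(Cl)cc(-c2nn(-c3cccc(NC(=O)Nc4ccc(Cl)c(Cl)c4)c3)cc2-c2ccncc2)c1` at 87% both lie within the scatter of it, as the steps of a number 3 percentage points lower from compound 1 to compound 3 (within the scatter) and a number 5 percentage points lower from compound 2 to compound 3 (within the scatter) show. Compound 4 `COc1cc(Cl)cc(-c2nn(-c3cccc(NC(=O)c4cccc(C(F)(F)F)c4)c3)cc2-c2ccncc2)c1` differs from compound 3 as follows: 3-(trifluoromethyl)phenyl in place of (3-(trifluoromethyl)phenyl)amino on a carbonyl carbon. For the measured compounds named here, no measured step touches the carbonyl carbon; the steps of a number 2 percentage points higher from compound 1 to compound 2 (within the scatter) and a number 3 percentage points lower from compound 1 to compound 3 (within the scatter) alter the aryl group only and were all within the scatter. Going by the values given here, the change to compound 4 therefore has no precedent, and the expectation rests only on the flat numbers across compounds 1 to 3. A step of a number 3 percentage points higher from compound 3 to compound 4 (within the scatter) is expected, not beyond the scatter. For compound 4 the estimate is 85%, between 65% and 100%.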

Compound 4, a percentage reported as activity, at one concentration (the size of the read-out at that concentration, not a potency): 92%
Estimate against measurement, compound 4: 7 percentage points below, within the range that was stated.
By their numbers in this assay, from the lowest: compounds 3, 1, 2 and 4 (each within the scatter of the next).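

In this assay, for the compounds shown here, the first change at the carbonyl carbon, 3-(trifluoromethyl)phenyl in place of (3-(trifluoromethyl)phenyl)amino, gives a number 10 percentage points higher from compound 3 to compound 4 (within the scatter) and so does not separate this amide from its urea. The other ureas give a number 5 percentage points higher from compound 2 to compound 4 (within the scatter) and a number 7 percentage points higher from compound 1 to compound 4 (within the scatter) and are not separated either, so losing the nitrogen and the amide hydrogen leaves no resolved effect at this concentration. No measurement shown bears on the reason for this result.

Open: whether an ether oxygen, a methylene carbon or an alkylamine on this carbonyl carbon would stay within the scatter.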